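The source may hold more compounds than are shown below. What is called first, only, known or untested is meant among the compounds shown, and "the series" means these compounds.

Among the measured compounds shown here, in a functional assay for inhibition of nuclear factor NF-kappa-B complex (Homo sapiens) (on this read-out lower numbers stand for stronger inhibition and higher numbers for weaker inhibition), compound 3 `COc1ccc2c(c1)OC(c1cc(OC)c(OC)c(OC)c1)C(C(=O)N(C)OC)=C2` gives 11700 nM, and this is the only number among the three values shown. Compound 1 `COc1ccc2c(c1)OC(c1cc(OC)c(OC)c(OC)c1)C(CO)=C2` gives > 50000 nM in this assay, a limit of the assay rather than a number. Compound 2 `COc1ccc2c(c1)OC(c1cc(OC)c(OC)c(OC)c1)C(C(=O)N1CCCCC1)=C2` likewise gives > 50000 nM, again a limit. Both sit at the limit of > 50000 nM in this assay, at which 2 of the 3 values shown sit. The step of an at least 4.2-fold lower number from compound 1 to compound 3 (0.63 log units; beyond the scatter) and the step of an at least 4.2-fold lower number from compound 2 to compound 3 (0.63 log units; beyond the scatter) are each readable only as a bound, while the step that the two limits leave unreadable from compound 1 to compound 2 cannot be read at all.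

Compound 4 `COc1ccc2c(c1)OC(c1cc(OC)c(OC)c(OC)c1)C(C(=O)OCCc1ccccc1)=C2` differs from compound 3 only at the carbonyl carbon: phenethyloxy in place of methoxy(methyl)amino on a carbonyl carbon. Of the measured steps, the exchange on the carbonyl carbon from compound 2 to compound 3 is the one that bears on this change, and it showed that what sits on the carbonyl matters at least modestly. For compound 4 a weakening is therefore expected, about a 1.7-fold higher number from compound 3 to compound 4 (0.23 log units; within the scatter). Compound 4 is expected to give 20000 nM, within 5000 nM to 80000 nM.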

Compound 4, half-maximal inhibitory concentration: 16200 nM
Compound 4: the middle estimate sits 1.2-fold (0.09 log units) above what was measured, within the range that was stated.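

In this assay, the carbonyl carbon tolerates a change from methoxy(methyl)amino to the larger phenethyloxy, which brings a six-membered aromatic ring of carbon only, and the step reads a 1.4-fold higher number from compound 3 to compound 4 (0.14 log units; within the scatter). Replacing piperidin-1-yl with phenethyloxy on the carbonyl carbon gives an at least 3.0-fold lower number from compound 2 to compound 4 (0.48 log units; beyond the scatter), and replacing hydroxymethyl with phenethyloxycarbonyl gives an at least 3.0-fold lower number from compound 1 to compound 4 (0.48 log units; beyond the scatter), so a second group at this place now gives a number rather than a limit. Those two steps are readable only as bounds, and the step between the two limits cannot be read: the limit of > 50000 nM in this assay, at which 2 of the 4 values shown sit.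

Going by these compounds, it remains open how a carboxylic acid, a methyl ester or a longer chain ending in the phenyl ring would read at this carbonyl carbon in this assay. Also open, on these data alone, is whether a secondary amine-derived amide would read like methoxy(methyl)amino or like piperidin-1-yl.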